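A few compounds are considered here, and "the series" means these few. Any claim that something is new, unique, unknown or untested is made for them only; others in the source may bear on it.

Compound 1 `Cc1ccccc1-c1n[nH]c(-c2ccccc2)n1` is the starting point; in a functional assay on the whole organism (Cricetulus griseus) with Cricetinae gen. sp. as the target (a higher number here means that more compound is needed for the effect, a lower number that less compound is needed), compound 1 gives 0.3 mg/kg; 0.3 mg/kg (2 entries). For the measured compounds named here, compound 2 `Cc1ccccc1-c1n[nH]c(-c2ccc(F)cc2)n1` carries a fluoro on the outer ring, and in this assay compound 2 gives 3.5 mg/kg, the only number recorded for it, with one further entry that gave no single number. Compound 3 `Cc1ccccc1-c1n[nH]c(-c2ccc(-c3ccccc3)cc2)n1` differs from compound 2 by phenyl in place of fluoro on an aromatic carbon. Going by the values given here, no measured pair shows what such a change does, so the expected step from compound 2 to compound 3 is a 1.2-fold lower number from compound 2 to compound 3 (0.07 log units; within the scatter), within scatter in either direction. The expected value for compound 3 is 3 mg/kg, ranging from 0.8 mg/kg to 12 mg/kg.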

Compound 3, dose for half-maximal effect: 10 mg/kg
Beside the measured number, compound 3's estimate is 3.3-fold (0.52 log units) below it; the range from low to high includes it.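

In this assay, putting phenyl in place of fluoro on this aromatic carbon gives a 2.9-fold higher number from compound 2 to compound 3 (0.46 log units; beyond the scatter), so more compound is needed for the effect. For the compounds shown here, this is the first measured step at this position, and it shows that the effect is still reached with a whole extra aromatic ring there, though at a higher dose. Nothing available explains this step.

As far as these compounds go, it remains open whether an amine or a methoxy group on this carbon would give a number closer to that of compound 1 at 0.3 mg/kg; 0.3 mg/kg (2 entries) or one as high as compound 3. A carboxylic acid or a longer chain in this place also remains untested in the compounds shown here.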